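This account rests on a few compounds, and the source may have more. Where it says the series, first, only, none or still open, it means among the compounds named here.

Going by the values given here, compound 2 `Clc1ccc(-c2ccc(-c3cc(-n4cnnn4)nn3-c3cccnc3)cc2)c(Cl)c1` gives 10600 nM in an assay on isolated protein for inhibition of methionine--tRNA ligase, cytoplasmic (Homo sapiens) (on this read-out lower numbers stand for stronger inhibition and higher numbers for weaker inhibition), the lower of the two numbers known here; compound 1 `O=C(O)c1cc(-c2ccc(-c3ccc(F)cc3)cc2)n(-c2ccc(Cl)cc2Cl)n1` gives 41300 nM in this assay, a gap beyond the usual scatter. The two differ in more than one place, so no single change between them can be read. Compound 3 `O=C(NCc1nn[nH]n1)c1cc(-c2ccc(-c3ccc(Cl)cc3Cl)cc2)n(-c2cccnc2)n1` differs from compound 2 in one place: ((2H-tetrazol-5-yl)methyl)carbamoyl in place of 1H-tetrazol-1-yl on an aromatic carbon. Among the compounds with values here, with no measured step of this kind to lean on, a modest step of a 1.4-fold higher number from compound 2 to compound 3 (0.15 log units; within the scatter) is expected, more likely toward a weaker read-out, though it may well stay within the scatter. Compound 3 is therefore estimated at 15000 nM in this assay, with a range from 4000 nM to 60000 nM.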

Compound 3, half-maximal inhibitory concentration: 13800 nM
Compound 3: middle estimate off by 1.1-fold (0.04 log units), on the high side; low and high end bracket the measured number.
By their numbers in this assay, from the lowest: compounds 2 and 3 (each within the scatter of the next); then compound 1.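

Going by these compounds alone, the exchange of 1H-tetrazol-1-yl for ((2H-tetrazol-5-yl)methyl)carbamoyl on this aromatic carbon amounts to a 1.3-fold higher number from compound 2 to compound 3 (0.11 log units; within the scatter) in this assay and is the first single-place comparison available. It shows that this position, two ring bonds from the ring atom that bears the pyridin-3-yl group, takes the larger group, with its carbonyl and amide hydrogen, without a shift beyond the scatter. The compounds shown leave open whether an amine or a methyl ester at this position on the core of compound 2 would read differently. Nothing measured here accounts for the two groups reading alike.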